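Fluoro in place of chloro: expected cytotoxicity of compound 3

The source may report more compounds than this note shows. Statements on the series, on what has been measured and on what is new or still open speak of the compounds shown alone.

Measured so far in an ADME assay on Huh-7 cells (Homo sapiens) for cytotoxicity, read by MTT assay, with a stated time of 72 h; on this read-out higher numbers stand for lower toxicity in this test and lower numbers for higher toxicity in this test:
- compound 1, `Cc1cc(=O)oc2cc(OCc3cn(-c4ccc(F)cc4)nn3)ccc12`, gives > 100 ug/mL, which is a limit of the assay.
- compound 2, `Cc1cc(=O)oc2cc(OCc3cn(-c4ccccc4Cl)nn3)ccc12`, gives > 100 ug/mL, which is a limit of the assay.

Compound 2 therefore sits at the limit of > 100 ug/mL in this assay, at which 2 of the 2 values shown sit, with no number of its own. For the measured compounds named here, the one step, a step that the two limits leave unreadable from compound 1 to compound 2, is not readable, since both ends are limits; it carries no information on size or direction.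

Compound 3, `Cc1cc(=O)oc2cc(OCc3cn(-c4ccccc4F)nn3)ccc12`, differs from compound 2 by fluoro in place of chloro on an aromatic carbon. Going by the values given here, no measured step bears on a halogen swap at this position, and the only comparison available, between compound 1 and compound 2, shows two limits. Nothing in the data points to a move beyond the scatter in this assay, so compound 3 is expected to give 150 ug/mL, most likely again reported as a limit, with a range from 60 ug/mL to 400 ug/mL; the expected step that the limit leaves unreadable from compound 2 to compound 3 is essentially none.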

Compound 3, half-maximal cytotoxic concentration: > 100 ug/mL
Compound 3: no number, only a limit (the forecaster's own chance of this, stated with the estimate: 85%); the middle value is on the limit's open side.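

No new step can be read among compound 1, compound 2 and compound 3, since each gives only a limit in this assay: the limit of > 100 ug/mL in this assay, at which 3 of the 3 values shown sit. Left open is where each compound lies beyond that limit, and whether the 4-fluorophenyl, 2-chlorophenyl and 2-fluorophenyl groups differ in this assay at all.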